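The source may report more compounds than this note shows. Statements on the series, on what has been measured and on what is new or still open speak of the compounds shown alone.

Compound 1, `COc1cc(-c2nn(-c3cccc(NC(=O)c4cccc(C(F)(F)F)c4)c3)cc2-c2ccncc2)ccc1Cl`, in a functional assay on PC-3 cells (Homo sapiens) for inhibition, read by sulforhodamine B assay, with a stated time of 48 h; on this read-out lower numbers stand for stronger inhibition of growth and higher numbers for weaker inhibition of growth: compound 1 gives 1230 nM.
Compound 2, `O=C(Nc1cccc(-n2cc(-c3ccncc3)c(-c3ccc(Cl)c(O)c3)n2)c1)Nc1cc(C(F)(F)F)cc(C(F)(F)F)c1`, in this assay: compound 2 gives 319 nM.
Compound 3, `COc1cc(-c2nn(-c3cccc(NC(=O)c4ccccc4)c3)cc2-c2ccncc2)ccc1Cl`, in this assay: compound 3 gives 426 nM.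

Compound 2 has the lowest number of the three. Its nearest neighbour is compound 3, and that gap lies within the scatter, so the two cannot be ranked; compound 1 is furthest off, with a gap beyond the scatter. Compound 4, `O=C(Nc1cccc(-n2cc(-c3ccncc3)c(-c3ccc(Cl)c(O)c3)n2)c1)Nc1cccc(C(F)(F)F)c1`, has not yet been measured. It differs from compound 2 by hydrogen in place of trifluoromethyl on an aromatic carbon.

Going by the values given here, only one measured step bears on this change: a 2.9-fold lower number from compound 1 to compound 3 (0.46 log units; beyond the scatter). That step, however, was made on an amide and removed the only trifluoromethyl present, whereas in compound 4 a second trifluoromethyl remains on the urea; the match is therefore loose. A step in the same direction but of smaller size is expected, a 1.5-fold lower number from compound 2 to compound 4 (0.16 log units; within the scatter), with the possibility that it falls within the scatter. Compound 4 is estimated at 220 nM, in the range from 90 nM to 550 nM.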

Compound 4, concentration for 50% growth inhibition: 948 nM
The estimate for compound 4 lay 4.3-fold (0.63 log units) below the measured number; measured number outside the range, above it.
By their numbers in this assay, from the lowest: compounds 2 and 3 (each within the scatter of the next); then compounds 4 and 1 (each within the scatter of the next).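

Going by these compounds alone, on the urea series, hydrogen in place of trifluoromethyl on an aromatic carbon gives a 3.0-fold higher number from compound 2 to compound 4 (0.47 log units; beyond the scatter), so in this assay this loss weakens growth inhibition, whereas the only earlier step on this change pointed the other way. This change therefore has no single direction across the compounds shown, even though a trifluoromethyl group remains on compound 4. The two results differ in direction, not merely by scatter: the same change on two cores in this assay, a 2.9-fold lower number (0.46 log units; beyond the scatter) from compound 1 to compound 3 and a 3.0-fold higher number (0.47 log units; beyond the scatter) from compound 2 to compound 4, 8.6-fold (0.93 log units) apart, beyond the scatter of two such steps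

The two pairs differ from each other in more than one place, including amide against urea and methoxy against hydroxy, so the compounds shown do not tell which of these differences goes with the reversal. Also open, as far as these compounds go, is how a urea carrying no trifluoromethyl at all would read, or one carrying a chlorine or a nitrile at this carbon.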